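This account rests on a few compounds, and the source may have more. Where it says the series, first, only, none or still open, it means among the compounds named here.

Compound 2 `O=C(/C=C/c1ccc2c(c1)B(O)OC2)c1ccc(I)cc1` and compound 1 `Cn1cccc1C(=O)/C=C/c1ccc2c(c1)B(O)OC2` share the same core and differ only in the group attached to the carbonyl carbon. In a toxicity assay on MCF-10A cells (Homo sapiens) for cytotoxicity, read by MTT assay, with a stated time of 48 h (a lower number here means a stronger inhibitor, a higher number a weaker inhibitor), compound 1 gives > 100000 nM, which is a limit of the assay and not a number. In this assay compound 2 gives > 100000 nM, again a limit rather than a measured number. The step that the two limits leave unreadable from compound 1 to compound 2 accordingly has no readable size, since both values sit at the limit of > 100000 nM in this assay, at which 2 of the 2 values shown sit. Where compound 2 stands is thus known only as a limit, and no ranking against compound 1 can be drawn from these two entries.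

Compound 3 `O=C(/C=C/c1ccc2c(c1)B(O)OC2)c1ccccc1F` differs from compound 2 by the change (2-fluorophenyl in place of 4-iodophenyl on a carbonyl carbon). Among the compounds with values here, the only measured step that touches this carbonyl position, a step that the two limits leave unreadable from compound 1 to compound 2, is unreadable, so it offers neither a direction nor a size for this new exchange. With both measured neighbours of the change resting at the same limit, no step beyond the scatter is expected, and compound 3 is expected to return a limit as well. The estimate for compound 3 in this assay is 100000 nM, within 50000 nM to 200000 nM. The step of a number no higher from compound 2 to compound 3 (the limit leaves the size open) is expected to be nothing beyond the scatter.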

Compound 3, half-maximal inhibitory concentration: 25400 nM
Estimate against measurement, compound 3: 3.9-fold (0.60 log units) above; measured number below the stated range.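

In this assay the group on the carbonyl carbon proves able to move the reading, which the earlier pair could not show, since the step between compound 1 and compound 2 stays unreadable: the change brings an at least 3.9-fold lower number from compound 2 to compound 3 (0.59 log units; beyond the scatter), and the exchange for the 1-methyl-1H-pyrrol-2-yl group brings an at least 3.9-fold lower number from compound 1 to compound 3 (0.59 log units; beyond the scatter). The change from compound 2 to compound 3 leaves the counts of heavy atoms, aromatic rings, hydrogen-bond donors and acceptors and the net charge as they were, so the step goes with the exchange of iodine for fluorine and the different location of the halogen, not with any of those counts. Both steps give only the least possible size, because each starts from a limit of the assay and not from a number: the limit of > 100000 nM in this assay, at which 2 of the 3 values shown sit.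

The two compounds leave the halogen and its location tied together, and a 4-fluorophenyl or a 2-iodophenyl group would be needed to separate them. Going by these compounds, how far the number can fall at this carbonyl carbon also remains open, for instance with an unsubstituted phenyl or with a phenyl ring carrying an amine or a carboxylic acid.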